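Thiophene amides of prolyl type: growth inhibition on MCF7 cells

The source may hold more compounds than are shown below. What is called first, only, known or untested is meant among the compounds shown, and "the series" means these compounds.

Two compounds of this set have been run in a functional assay on MCF7 cells (Homo sapiens) for inhibition; on this read-out lower numbers stand for stronger inhibition of growth and higher numbers for weaker inhibition of growth. Compound 1 `O=C1CC[C@@H](COC(=O)c2ccsc2NC(=O)[C@@H]2CCCN2)N1` gives 148 ug/mL in this assay. Compound 2 `COC(=O)c1sccc1NC(=O)[C@@H]1CCCN1` gives 163 ug/mL in this assay; the two numbers lie within the scatter of each other, so compound 1 is not set apart from compound 2 on the data so far. Both compounds inhibit growth only weakly on this read-out.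

Compound 3 `CCOC(=O)c1ccsc1NC(=O)[C@@H]1CCCN1` has not been measured. It differs from compound 1 by methyl in place of 5-oxopyrrolidin-2-yl on a saturated chain carbon bound to an oxygen next to a carbonyl group. For the measured compounds named here, no measured pair in the set shows this step directly. Compound 2 gives 163 ug/mL in this assay and compound 1 gives 148 ug/mL, both numbers of the same size. On that basis compound 3 is expected to sit in the same region, with the step of a 1.0-fold higher number from compound 1 to compound 3 (0.01 log units; within the scatter) estimated to stay within the scatter. The estimate for compound 3 in this assay is 150 ug/mL, with a range from 70 ug/mL to 320 ug/mL.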

Compound 3, concentration for 50% growth inhibition: > 250 ug/mL
Compound 3 was reported as a limit (the forecaster's own chance of this, stated with the estimate: 15%); middle value at least 1.6-fold (0.22 log units) away from the limit.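

Compound 3 is reported only as a limit in this assay, so it has no exact position on this read-out: the limit of > 250 ug/mL in this assay, at which 1 of the 3 values shown sits. Methyl in place of 5-oxopyrrolidin-2-yl, the same difference as (5-oxopyrrolidin-2-yl)methyl to ethyl, is the first single-place change available at this position, and it reads as an at least 1.6-fold higher number from compound 1 to compound 3 (0.22 log units; that floor lies within the scatter). The floor of this step does not set the two compounds apart, yet the limit leaves room for a larger true step, so the contribution of 5-oxopyrrolidin-2-yl remains unsettled.

Going by these compounds, it remains open how an amine, a carboxylic acid or a longer chain at this position would read. The compounds shown also do not separate the ring of 5-oxopyrrolidin-2-yl from its hydrogen-bond donor and acceptor.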